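The source may report more compounds than this note shows. Statements on the series, on what has been measured and on what is new or still open speak of the compounds shown alone.

Measured in a functional assay on NCI-H460 cells (Homo sapiens) for inhibition, read by MTT assay, with a stated time of 24 h, tested at 1 ug/mL; a higher number here means more inhibition of growth at the concentration tested, a lower number less inhibition of growth
compound 1 `CC(=O)SCCC(CCCCC(=O)O)SC(C)=O` gives 9.89%
compound 2 `O=C(CCCCC(S)CCS)Nc1cccc(C(F)(F)F)c1` gives 8.26%

Compound 1 and compound 2 lie within the scatter of each other, and these two numbers are all the series offers so far. Compound 3 `CC(=O)SCCC(CCCCC(=O)Nc1ccccc1Cl)SC(C)=O` keeps the core of compound 1 and carries (2-chlorophenyl)amino in place of hydroxy on a carbonyl carbon. Going by the values given here, no measured step covers this change. Compound 2 also carries an aromatic ring and gives 8.26%, so no step beyond the scatter is expected in this assay, with a small rise the likeliest direction. The estimated step is a number 2.1 percentage points higher from compound 1 to compound 3 (within the scatter). Compound 3 is estimated at 12%, with an expected range of 3% to 30%.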

Compound 3, percent growth inhibition at one concentration: 13.2%
For compound 3 the middle estimate is 1.2 percentage points below the measured one; the measured number falls inside the stated range.
By their numbers in this assay, from the lowest: compounds 2, 1 and 3 (each within the scatter of the next).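

In this assay, (2-chlorophenyl)amino in place of hydroxy on a carbonyl carbon gives a number 3.3 percentage points higher from compound 1 to compound 3 (within the scatter), so this exchange removes the free acid and adds an aromatic ring without a step beyond the scatter. At this position, the larger group is therefore tolerated at the single concentration tested, but no gain can be claimed. Still open, from the compounds shown here alone, is whether any group here can move the number beyond the scatter: a phenylamino group without chlorine or a simple methylamino group on the same carbonyl carbon would test this. No measurement at hand bears on a cause for this step.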